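Replacing the Hydroxy Group of Compound 3

The source may report more compounds than this note shows. Statements on the series, on what has been measured and on what is new or still open speak of the compounds shown alone.

Values in a functional assay on HCT-116 cells (Homo sapiens) for inhibition, read by MTT assay, with a stated time of 48 h; a higher number here means a weaker inhibitor, a lower number a stronger inhibitor:
Compound 1 `COc1ccc(CN(C(C)=O)c2cc(OC)c(OC)c(OC)c2)cc1O`: 270 nM
Compound 2 `COc1ccc(CN(C(=O)C=C(C)C)c2cc(OC)c(OC)c(OC)c2)cc1O`: 290 nM
Compound 3 `COc1ccc(CN(C(=O)CO)c2cc(OC)c(OC)c(OC)c2)cc1O`: 520 nM

Compound 3, at 520 nM, is not separated from the other two measured compounds: the data show a 1.9-fold higher number from compound 1 to compound 3 (0.28 log units; within the scatter) and a 1.8-fold higher number from compound 2 to compound 3 (0.25 log units; within the scatter). In compound 4 `COc1ccc(CN(C(=O)C[Se]C#N)c2cc(OC)c(OC)c(OC)c2)cc1O`, the hydroxy of compound 3 gives way, on a saturated chain carbon bound to a carbonyl carbon, to a group with no common name: a group of 3 heavy atoms (1 carbon, 1 nitrogen, 1 selenium; no ring) in place of one oxygen atom, on a saturated chain carbon bound to a carbonyl carbon.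

The closest measured step is a 1.9-fold higher number from compound 1 to compound 3 (0.28 log units; within the scatter), which falls on that same carbon. A larger exchange on the carbonyl carbon, a 1.1-fold higher number from compound 1 to compound 2 (0.03 log units; within the scatter), also stays within the scatter. Going by the values given here, no measured compound contains selenium, so these steps offer only indirect guidance, and the uncertainty remains wide. No step beyond the scatter is therefore expected in this assay. The estimated change is a 1.7-fold lower number from compound 3 to compound 4 (0.24 log units; within the scatter), which is expected to stay within the scatter. For compound 4 the estimated value is 300 nM, with an expected range of 90 nM to 1000 nM.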

Compound 4, half-maximal inhibitory concentration: 310 nM
For compound 4 the middle estimate is 1.0-fold (0.01 log units) below the measured one; measured number inside the range.
By their numbers in this assay, from the lowest: compounds 1, 2, 4 and 3 (each within the scatter of the next).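

In this assay, the selenium-containing group gives a 1.7-fold lower number from compound 3 to compound 4 (0.22 log units; within the scatter) against the hydroxy and a 1.1-fold higher number from compound 1 to compound 4 (0.06 log units; within the scatter) against the hydrogen, so this saturated chain carbon bound to a carbonyl carbon, previously seen carrying only those two, also carries a group of this kind, with selenium and a triple bond, without a step beyond the scatter. The exchange on the carbonyl carbon gives a 1.1-fold higher number from compound 2 to compound 4 (0.03 log units; within the scatter), so this larger replacement for the 2-methylprop-1-en-1-yl group also stays within the scatter. Nothing available explains these numbers or shows what the selenium contributes.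

The compounds shown leave open whether a sulfur atom in place of the selenium would give a similar number. They also leave open whether an amine on the same carbon, or a longer chain bearing the selenium, would produce a step beyond the scatter.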